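A few compounds are considered here, and "the series" means these few. Any claim that something is new, unique, unknown or untested is made for them only; others in the source may bear on it.

Compound 2 (`N#Cc1ccc(Nc2nccc([C@@H](O)c3ccc(-c4ccc(C#N)cc4)cc3Cl)n2)cc1`) reads 4250 nM in an ADME assay on MT4 cells (Homo sapiens) for cytotoxicity, read by MTT assay, with a stated time of 5 days (on this read-out higher numbers stand for lower toxicity in this test and lower numbers for higher toxicity in this test), and stays within the scatter of compound 1 (`N#Cc1ccc(Nc2nccc(C(O)c3ccc(-c4ccc(C#N)cc4)cc3Cl)n2)cc1`), which reads 7540 nM with no configuration drawn at its stereocentre. With the opposite configuration to compound 2, compound 3 (`N#Cc1ccc(Nc2nccc([C@H](O)c3ccc(-c4ccc(C#N)cc4)cc3Cl)n2)cc1`) reads 28100 nM and stands clearly higher than both.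

Compound 4 (`N#Cc1ccc(Nc2nccc([C@@H](O)c3ccc(-c4ccc(C#N)cc4)cc3F)n2)cc1`) keeps the configuration of compound 2 and carries fluoro in place of chloro on an aromatic carbon (fluoro in place of chloro on an aromatic carbon, ortho to a large group).

All measured steps concern configuration alone: a 1.8-fold lower number from compound 1 to compound 2 (0.25 log units; within the scatter) and a 3.7-fold higher number from compound 1 to compound 3 (0.57 log units; beyond the scatter) set the drawn forms against the undefined one (the fact that one of compounds 1 and 2 is drawn with a defined configuration and the other without, at the place where they differ, (the fact that one of compounds 1 and 3 is drawn with a defined configuration and the other without, at the place where they differ)). The largest, a 6.6-fold higher number from compound 2 to compound 3 (0.82 log units; beyond the scatter), comes with a pure change of configuration (the fact that compounds 2 and 3 differ only in the configuration as drawn). None of them changes the halogen, so they give no size for this exchange.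

From compound 2 at 4250 nM no step beyond the scatter is expected in this assay for the halogen exchange. The expected size is a 1.4-fold higher number from compound 2 to compound 4 (0.15 log units; within the scatter) and this estimate stays within the scatter. For compound 4 the estimate is 6000 nM with 2200 nM to 18000 nM as the expected range.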

Compound 4, half-maximal cytotoxic concentration: 7500 nM
Compound 4: the middle estimate sits 1.3-fold (0.10 log units) below what was measured; low and high end bracket the measured number.
By their numbers in this assay, from the lowest: compounds 2, 4 and 1 (each within the scatter of the next); then compound 3.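

In this assay, going by these compounds alone, the exchange of chloro for fluoro on this aromatic carbon, with the configuration of compound 2 kept, gives a 1.8-fold higher number from compound 2 to compound 4 (0.25 log units; within the scatter) and is the first size available for a change at this place. Between these two halogens the read-out draws no distinction, while the pure change of configuration gives a 6.6-fold higher number from compound 2 to compound 3 (0.82 log units; beyond the scatter) and remains the larger effect in the series so far. Nothing measured here speaks to the reason for this outcome.

On these data alone, both groups compared are single halogen atoms, so the response to methyl, methoxy or an amine at this place stays open. Also open is whether the gap between the two configurations persists with fluoro, as the compounds shown carry fluoro in only one configuration.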